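Swapping oxetan-3-yl for (hydroxymethyl)carbonyl in compound 2

This account rests on a few compounds, and the source may have more. Where it says the series, first, only, none or still open, it means among the compounds named here.

Compound 1 `C[C@@H](Oc1cc(C(=O)N(C)C)ccc1Nc1nc(O[C@H]2CC[C@@](C)(O)CC2)c2c(Cl)c[nH]c2n1)C(F)(F)F` gives 4350 nM
Compound 2 `COc1cc(N2CCN(C3COC3)CC2)ccc1Nc1nc(O[C@H]2CCOC(C)(C)C2)c2cc[nH]c2n1` gives 4430 nM

Both compounds were measured in an ADME assay on the whole organism (Rattus norvegicus) for pharmacokinetics, at a dose of 10 mg/kg by the oral route (a lower number here means less compound in the circulation, a higher number more compound in the circulation at the dose given), after oral dosing in the rat. There, compound 2 at 4430 nM and compound 1 at 4350 nM stand level, within the scatter of each other. Compound 3 `COc1cc(N2CCN(C(=O)CO)CC2)ccc1Nc1nc(O[C@H]2CCOC(C)(C)C2)c2cc[nH]c2n1` keeps the frame of compound 2 and carries one change, ((hydroxymethyl)carbonyl in place of oxetan-3-yl on an amine nitrogen in a ring), which puts (hydroxymethyl)carbonyl in place of oxetan-3-yl on an amine nitrogen in a ring. Cut one bond further out, the same difference reads 4-(oxetan-3-yl)piperazin-1-yl to 4-((hydroxymethyl)carbonyl)piperazin-1-yl. Among the measured compounds shown here, no measured pair isolates this change, so the only anchor is compound 2 at 4430 nM and the expectation is a loose one. A moderate fall in this assay is expected, with the estimated step of a 2.0-fold lower number from compound 2 to compound 3 (0.30 log units; within the scatter), though no change beyond the scatter would not be surprising. For compound 3 the estimated value is 2200 nM, with the expected range running from 600 nM to 7000 nM.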

Compound 3, maximal plasma concentration: 2530 nM
Estimate against measurement, compound 3: 1.2-fold (0.06 log units) below; the range from low to high includes it.
By their numbers in this assay, from the lowest: compounds 3, 1 and 2 (each within the scatter of the next).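

Among the compounds shown here, this is the first pair that differs in one place, and it gives a direct reading for the amine nitrogen in the six-membered non-aromatic ring: in this assay, replacing oxetan-3-yl with (hydroxymethyl)carbonyl gives a 1.8-fold lower number from compound 2 to compound 3 (0.24 log units; within the scatter) at the given oral dose. The change removes the four-membered ring and brings in a double bond outside aromatic rings and a hydrogen-bond donor, yet the step remains within the scatter, so this single pair shows no clear effect of the exchange on the maximal plasma concentration. No supporting measurement bears on why the step has this size.

On these data alone, it remains open what an acetyl group, a carboxylic acid or a longer hydroxyalkyl chain on the same ring nitrogen would give in this assay. Also open is whether this exchange would behave in the same way on a different frame, since one pair cannot establish a pattern, and whether the maximal plasma concentration alone reflects the wider exposure of these compounds.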